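Cytotoxicity notes on a hydrazone and its methoxy analogue

The compounds below may be only part of what the source reports. "The series", "measured", "known", "first", "only" and "open" are said of these compounds alone.

Measured so far in an ADME assay on Vero cells (Chlorocebus sabaeus) for cytotoxicity, with a stated time of 72 h, tested at 50 ug/mL; on this read-out higher numbers stand for a stronger effect at the one concentration tested and lower numbers for a weaker effect:
- compound 1, `Cc1ccc(N2CCn3c2n[nH]c(=O)c3=O)cc1`: 0%
- compound 2, `Cc1ccc(N2CCN/C2=N\N)cc1`: 9%
- compound 3, `Cc1cccc(N2CCn3c2n[nH]c(=O)c3=O)c1C`: 18%

All three numbers are small. Compound 2 sits between compound 1 and compound 3 on the read-out, but both gaps are within the scatter of repeated measurements, so no order among the three can be read and none of them can be called the more or less cytotoxic. No pair of these compounds differs in only one place, so no single structural step has yet been measured in this assay.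

The next compound, compound 4, `COc1ccc(N2CCN/C2=N\N)cc1`, is built from compound 2 by the change (methoxy in place of methyl on an aromatic carbon). Among the compounds with values here, nothing among the measured compounds shows what a methoxy in place of a methyl does on this read-out. Given that compound 1, compound 2 and compound 3 all lie within the scatter of one another, the step is expected to be none beyond the scatter, estimated as no change at the digits printed from compound 2 to compound 4 (within the scatter) in this assay. Compound 4 is therefore expected to give about 9%, within a range from 0% to 25%.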

Compound 4, a percentage reported as inhibition, at one concentration (the size of the read-out at that concentration, not a potency): 0%
Compound 4: the middle estimate sits 9 percentage points above what was measured; measured number inside the range.
By their numbers in this assay, from the lowest: compounds 1, 4, 2 and 3 (each within the scatter of the next, the first and the last beyond it).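

Within the data shown here, the first step that differs in one place is methoxy in place of methyl on an aromatic carbon, para to a group of 7 heavy atoms, and in this assay it reads (a number 9 percentage points lower from compound 2 to compound 4 (within the scatter)). This exchange adds one oxygen and one hydrogen-bond acceptor at this position, yet the read-out stays within the scatter at the one concentration tested, so no effect of the change can be claimed. No measurement at hand bears on a cause for this step.

As far as these compounds go, whether an amine, a carboxylic acid or a longer chain on the same aromatic carbon would also stay within the scatter remains open. Also open are whether methoxy in place of methyl reads the same on the core of compound 1 and how any of these compounds behaves at other concentrations.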